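This account rests on a few compounds, and the source may have more. Where it says the series, first, only, none or still open, it means among the compounds named here.

Notes on the series. Compound 1 `O=C(COc1ccccc1)Nc1nc(-c2ccc(Br)cc2)cs1` carries a phenoxy group and a bromo group on the shared core. In a functional assay on Ehrlich cells (Mus musculus) for cytotoxicity, read by MTT assay, with a stated time of 48 h (on this read-out higher numbers stand for weaker inhibition and lower numbers for stronger inhibition), compound 1 gives 37200 nM. Compound 2 `Cc1ccccc1OCC(=O)Nc1nc(-c2ccc(Br)cc2)cs1` differs from compound 1 by methyl in place of hydrogen on an aromatic carbon; in this assay compound 2 gives 44900 nM, a step of a 1.2-fold higher number from compound 1 to compound 2 (0.08 log units; within the scatter). Compound 3 `O=C(COc1ccccc1)Nc1nc(-c2ccc(Cl)cc2)cs1` differs from compound 1 by chloro in place of bromo on an aromatic carbon; in this assay compound 3 gives 55500 nM, a step of a 1.5-fold higher number from compound 1 to compound 3 (0.17 log units; within the scatter). All three numbers lie within the scatter of one another, so no order among them is drawn.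

Compound 4 `Cc1ccccc1OCC(=O)Nc1nc(-c2ccc(Cl)cc2)cs1` is not yet measured. It differs from compound 3 by methyl in place of hydrogen on an aromatic carbon, the same change as from compound 1 to compound 2, made here on the core of compound 3, which differs from the core of compound 1 by chloro in place of bromo on an aromatic carbon. Both instances share the same place, on an aromatic carbon of a six-membered aromatic ring of carbon only, ortho to a large group. In this assay, among the compounds with values here, the expected step is a 1.2-fold higher number from compound 3 to compound 4 (0.07 log units; within the scatter), which rests on the single earlier instance, a 1.2-fold higher number from compound 1 to compound 2 (0.08 log units; within the scatter), a step that stayed within the scatter. Compound 4 is accordingly estimated at 65000 nM in this assay, with a range from 35000 nM to 120000 nM.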

Compound 4, half-maximal inhibitory concentration: 62300 nM
Compound 4: middle estimate off by 1.0-fold (0.02 log units), on the high side; the range from low to high includes it.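

In this assay the two new steps, a 1.1-fold higher number from compound 3 to compound 4 (0.05 log units; within the scatter) and a 1.4-fold higher number from compound 2 to compound 4 (0.14 log units; within the scatter), are both small, so they show that neither change has a distinct effect here that could be followed from core to core, and they do not show that a step of real size would carry over in the same way. Methyl in place of hydrogen reads alike on the bromo and chloro cores: the same change on two cores in this assay, a 1.2-fold higher number (0.08 log units; within the scatter) from compound 1 to compound 2 and a 1.1-fold higher number (0.05 log units; within the scatter) from compound 3 to compound 4, 1.1-fold (0.03 log units) apart, within the scatter of two such steps

Chloro in place of bromo likewise reads alike with and without the methyl: the same change on two cores in this assay, a 1.5-fold higher number (0.17 log units; within the scatter) from compound 1 to compound 3 and a 1.4-fold higher number (0.14 log units; within the scatter) from compound 2 to compound 4, 1.1-fold (0.03 log units) apart, within the scatter of two such steps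

The compounds shown leave open what an amine, a carboxylic acid or a longer chain in place of the methyl would do on the shared core. Also open, on these data alone, is whether any such group would give a step beyond the scatter, and whether that step would then hold on both the bromo and the chloro core.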